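A ring at the end of a saturated chain

The source may hold more compounds than are shown below. What is called first, only, known or untested is meant among the compounds shown, and "the series" means these compounds.

Values in a functional assay on A549 cells (Homo sapiens) for cytotoxicity, read by MTT assay, with a stated time of 48 h (on this read-out higher numbers stand for weaker inhibition and lower numbers for stronger inhibition), for the measured compounds
Compound 1 `C=C1C(=O)O[C@H]2CC3=C[C@H](C/C(C)=C/[C@@H](OC(=O)c4ccc(C(C)=O)cc4)[C@H]12)OC3=O` gives 2300 nM
Compound 2 `C=C1C(=O)O[C@H]2CC3=C[C@H](C/C(C)=C/[C@@H](OC(=O)/C=C/c4cccc(OC)c4)[C@H]12)OC3=O` gives 6200 nM
Compound 3 `C=C1C(=O)O[C@H]2CC3=C[C@H](C/C(C)=C/[C@@H](OC(=O)CCCCC)[C@H]12)OC3=O` gives > 10000 nM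

Compound 3 reads > 10000 nM as its result, and this is a limit of the assay, not a number. Compound 4 `C=C1C(=O)O[C@H]2CC3=C[C@H](C/C(C)=C/[C@@H](OC(=O)CC4CCCCC4)[C@H]12)OC3=O` keeps the shared core and alters only the end of the chain: cyclohexyl in place of butyl on a saturated chain carbon bound to a carbonyl carbon with cyclohexyl in place of butyl on a saturated chain carbon bound to a carbonyl carbon.

Among the measured compounds shown here, no measured step makes this exact change. The nearest steps both end at pentyl on a carbonyl carbon. Replacing 4-acetylphenyl gave an at least 4.3-fold higher number from compound 1 to compound 3 (0.63 log units; beyond the scatter) and replacing 2-(3-methoxyphenyl)ethenyl gave an at least 1.6-fold higher number from compound 2 to compound 3 (0.20 log units; that floor lies within the scatter) as its result. Compound 4 brings back neither of those groups, only a non-aromatic ring of carbon. No step beyond the scatter is therefore expected in this assay and another limit is quite possible. The estimated change is a number no higher from compound 3 to compound 4 (the limit leaves the size open) for this swap. Compound 4 is estimated at 10000 nM with an expected range from 5000 nM to 20000 nM as its likely span.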

Compound 4, half-maximal inhibitory concentration: 6900 nM
Compound 4: middle estimate off by 1.4-fold (0.16 log units), on the high side; low and high end bracket the measured number.
By their numbers in this assay, from the lowest: compound 1; then compounds 2 and 4 (each within the scatter of the next). At a limit, above all of these: compound 3.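

this assay compound 3 gives > 10000 nM, which is a limit and not a number. Cyclohexyl in place of butyl on a saturated chain carbon bound to a carbonyl carbon brings a ring-ended but non-aromatic chain to a real number, yet the swap reads only as an at least 1.4-fold lower number from compound 3 to compound 4 (0.16 log units; that floor lies within the scatter), and its true size stays open because compound 3 stands at a limit: the limit of > 10000 nM in this assay, at which 1 of the 4 values shown sits. Among the compounds shown, a group on this carbonyl carbon therefore need not hold an aromatic ring to give a measurable value, since replacing the 2-(3-methoxyphenyl)ethenyl group with cyclohexylmethyl gives a 1.1-fold higher number from compound 2 to compound 4 (0.05 log units; within the scatter), while replacing 4-acetylphenyl with cyclohexylmethyl gives a 3.0-fold higher number from compound 1 to compound 4 (0.48 log units; beyond the scatter), so compound 1 keeps a real margin over compound 4.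

The compounds shown leave open whether the ring itself matters or only the carbon count, which a longer straight chain such as octyl, or a cyclopentyl ring at the same chain end, could help to separate. They also leave open what a phenyl ring at that chain end would do, or an amine or a hydroxyl group placed on the cyclohexyl ring.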